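Bromo in Place of Iodo on the Carbonyl-Bound Chain Carbon

The source may hold more compounds than are shown below. What is called first, only, known or untested is meant among the compounds shown, and "the series" means these compounds.

Within the data shown here, compound 1 `Cc1cn(C2CC(O)C(CCC(=O)CI)O2)c(=O)[nH]c1=O` is the only compound that yields a number in a functional assay on L1210 cells (Mus musculus) for inhibition, with a stated time of 48 h (on this read-out lower numbers stand for stronger inhibition and higher numbers for weaker inhibition), where compound 1 gives 20000 nM. Compound 2 `Cc1cn(C2CC(O)C(CNC(=O)c3ccc(C(=O)CBr)cc3)O2)c(=O)[nH]c1=O` reaches only a limit in this assay, namely > 70000 nM; (the limit of > 70000 nM in this assay, at which 1 of the 2 values shown sits). Compound 3 `Cc1cn(C2CC(O)C(CCC(=O)CBr)O2)c(=O)[nH]c1=O` differs from compound 1 by bromo in place of iodo on a saturated chain carbon bound to a carbonyl carbon. Among the measured compounds shown here, no step between measured compounds is known, so the expected step of a 1.5-fold higher number from compound 1 to compound 3 (0.18 log units; within the scatter) is a slight weakening, about at the edge of the scatter. Compound 3 is estimated at 30000 nM in this assay, with a range from 10000 nM to 90000 nM.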

Compound 3, half-maximal inhibitory concentration: 110000 nM
The estimate for compound 3 lay 3.7-fold (0.56 log units) below the measured number; measured number above the stated range.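

In this assay, the halogen on this saturated chain carbon bound to a carbonyl carbon is not interchangeable: bromo in place of iodo gives a 5.5-fold higher number from compound 1 to compound 3 (0.74 log units; beyond the scatter), a weakening that compound 1 alone could not show. Among these compounds, this is the first readable step, and it isolates the halogen as the only difference. Nothing shown accounts for this step. On these data alone, whether chloro at this carbon would weaken inhibition further remains open. So does what an amine in place of the halogen would do.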